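A new side group on a growth inhibitor

This account rests on a few compounds, and the source may have more. Where it says the series, first, only, none or still open, it means among the compounds named here.

In a functional assay on KB cells (Homo sapiens) for antiproliferative activity, read by sulforhodamine B assay, with a stated time of 3 days (a higher number here means a weaker inhibitor of growth, a lower number a stronger inhibitor of growth), compound 1 `COc1ccc(NC(=O)c2cccc(Nc3ncc(F)c(Nc4ccc(F)cc4)n3)c2)cc1` gives > 10000 nM, which is a limit of the assay and not a number. Compound 2 `O=C(c1cccc(Nc2ncc(F)c(Nc3ccc(F)cc3)n2)c1)N1CCCCC1` gives 14800 nM, and compound 3 `O=C(Nc1cccc(Nc2ncc(F)c(Nc3ccc(F)cc3)n2)c1)c1ccncc1` gives 5280 nM, the lower of the two actual numbers.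

Compound 4 `O=C(Nc1cc(Cl)cc(Cl)c1)c1cccc(Nc2ncc(F)c(Nc3ccc(F)cc3)n2)c1` has not yet been measured. It carries (3,5-dichlorophenyl)carbamoyl in place of ((pyridin-4-yl)carbonyl)amino, on an aromatic carbon, meta to a large group ((3,5-dichlorophenyl)carbamoyl in place of ((pyridin-4-yl)carbonyl)amino on an aromatic carbon). Its closest measured relative is compound 1, which has (4-methoxyphenyl)carbamoyl at that place. Within the data shown here, two measured steps bear on the change: an at least 1.8-fold lower number from compound 1 to compound 3 (0.27 log units; that floor lies within the scatter), and a 2.8-fold lower number from compound 2 to compound 3 (0.45 log units; beyond the scatter). Neither step is large, and the first runs in the reverse sense of the change to compound 4, so only a small move towards a higher number is expected. In this assay the expected change is a 1.7-fold higher number from compound 3 to compound 4 (0.23 log units; within the scatter). The estimate for compound 4 is 9000 nM, with an expected range of 2500 nM to 25000 nM.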

Compound 4, concentration for 50% growth inhibition: 20100 nM
Estimate against measurement, compound 4: 2.2-fold (0.35 log units) below; the range from low to high includes it.
By their numbers in this assay, from the lowest: compound 3; then compounds 2 and 4 (each within the scatter of the next).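

In this assay, putting (3,5-dichlorophenyl)carbamoyl in place of ((pyridin-4-yl)carbonyl)amino gives a 3.8-fold higher number from compound 3 to compound 4 (0.58 log units; beyond the scatter), so a carbamoyl group bearing an aromatic ring does not by itself keep the low number of compound 3. With a 1.4-fold higher number from compound 2 to compound 4 (0.13 log units; within the scatter), this assay does not separate (3,5-dichlorophenyl)amino from piperidin-1-yl on the carbonyl carbon, although one is an aromatic ring and the other is not. The step involving compound 1 cannot be read, since compound 1 stands at a limit of the assay and not a number: the limit of > 10000 nM in this assay, at which 1 of the 4 values shown sits.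

Compound 3 and compound 4 differ both in the ring and in which way round the amide sits, so the compounds shown do not tell which of the two matters. A (pyridin-4-yl)carbamoyl group or a benzoylamino group at this place would pull those two apart.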